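The source may report more compounds than this note shows. Statements on the series, on what has been measured and on what is new or still open speak of the compounds shown alone.

Measured so far:
Compound 1, `COc1cc2c(cc1OC)C(CC(=O)Nc1ccccc1C)CC2`: 25.9%
Compound 2, `COc1cc2c(cc1OC)C(CC(=O)Nc1cccnc1)CC2`: 35.2%

In a functional assay on the whole organism (strain Wistar) for inhibition, with Rattus norvegicus as the target, read by paw edema, with a stated time of 6 h, at a dose of 100 mg/kg (on this read-out higher numbers stand for more inhibition at the one dose given (going by the name of the read-out) and lower numbers for less inhibition), compound 1 gives 25.9% and compound 2 gives 35.2%. The two numbers lie within the scatter of each other, as the step of a number 9.3 percentage points higher from compound 1 to compound 2 (within the scatter) shows, so the inhibition in this assay of compound 2 cannot be said to be higher than that of compound 1.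

Compound 3, `COc1cc2c(cc1OC)C(CC(=O)Nc1ccncc1)CC2`, has not yet been measured. It differs from compound 2 only in one place: pyridin-4-yl in place of pyridin-3-yl on an amide-type nitrogen. Among the measured compounds shown here, the single measured step, a number 9.3 percentage points higher from compound 1 to compound 2 (within the scatter), swaps a quite different group onto the same nitrogen and says nothing about how a pyridin-3-yl compares with a pyridin-4-yl; no measured pair makes that comparison. With nothing pointing either way, the expected change is none beyond the scatter, namely a number 2.2 percentage points lower from compound 2 to compound 3 (within the scatter). Compound 3 is therefore estimated at 33%, with a range from 18% to 48%.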

Compound 3, a percentage reported as inhibition, in the whole organism at one dose (the size of the read-out at that dose, not a potency): 46.3%
Compound 3: middle estimate off by 13.3 percentage points, on the low side; measured number inside the range.
By their numbers in this assay, from the lowest: compounds 1 and 2 (each within the scatter of the next); then compound 3.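

On the amide-type nitrogen, the same ring atoms joined differently now give a readable difference in this assay: pyridin-4-yl in place of pyridin-3-yl gives a number 11.1 percentage points higher from compound 2 to compound 3 (beyond the scatter) and so shows that this position responds to how the pyridine ring is attached, not only to which ring is present. Pyridin-4-yl in place of 2-methylphenyl gives a number 20.4 percentage points higher from compound 1 to compound 3 (beyond the scatter) and is the first replacement of 2-methylphenyl here to lie beyond the scatter, although both new steps are modest. Nothing available explains either difference.

Going by these compounds, the effect on this nitrogen of a pyridin-2-yl, an unsubstituted phenyl or a saturated ring such as piperidin-4-yl remains open. So does the effect of changing the methoxy groups on the shared core, and with a single dose, how the compounds compare at other doses.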